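The source may report more compounds than this note shows. Statements on the series, on what has been measured and on what is new or still open speak of the compounds shown alone.

Measured compounds:
compound 1 `CCCCNc1nc(C)nc2c1cnn2-c1ccccc1` gives 2400 nM in a functional assay on G-361 cells (Homo sapiens) for cytotoxicity, read by sulforhodamine B assay; on this read-out lower numbers stand for stronger inhibition of growth and higher numbers for weaker inhibition of growth
compound 2 `Cc1nc(NCc2ccccc2)c2cnn(-c3ccccc3)c2n1` gives > 100000 nM in this assay

The account follows the step from compound 1 to compound 3 `CCCCNc1nc(CC)nc2c1cnn2-c1ccccc1`. Going by the values given here, compound 1 holds the only number given in this assay. Compound 2 gives a limit in this assay, not a number (the limit of > 100000 nM in this assay, at which 1 of the 2 values shown sits). Compound 3 differs from compound 1 by methyl in place of hydrogen on a saturated chain carbon bound to an aromatic carbon. Among the compounds with values here, the one measured step, an at least 41-fold higher number from compound 1 to compound 2 (1.61 log units; beyond the scatter), sits at another place and gives no guide to this change. For compound 3 no step beyond the scatter is expected, so no change at the digits printed from compound 1 to compound 3 (within the scatter). Compound 3 is therefore estimated at 2400 nM, within 1000 nM to 6000 nM.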

Compound 3, concentration for 50% growth inhibition: 2020 nM
Beside the measured number, compound 3's estimate is 1.2-fold (0.07 log units) above it; measured number inside the range.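

In this assay the methyl in place of hydrogen on a saturated chain carbon bound to an aromatic carbon gives a 1.2-fold lower number from compound 1 to compound 3 (0.07 log units; within the scatter) and so shows that this position takes the change from methyl to ethyl without a step beyond the scatter. The earlier compounds shown here held a change only on a saturated chain carbon bound to a nitrogen on an aromatic ring, so they said nothing about this position. Nothing shown here speaks to a cause for this result.

From the compounds shown here alone, whether a longer chain, an amine or a carboxylic acid at this position would also stay within the scatter remains open.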